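Repeating a chloro step on two related cores

The compounds below may be only part of what the source reports. "The series", "measured", "known", "first", "only" and "open" are said of these compounds alone.

Compound 1 `CN1CCN(c2nc(-c3cccc(Cl)c3)nc3[nH]cnc23)CC1`: in an assay on cells for displacement of a labelled ligand from adenosine receptor A3 (Homo sapiens), read by scintillation counting and radioligand binding, with a stated time of 180 min, tested at 10 uM (a higher number here means more inhibition at the concentration tested (going by the name of the read-out), a lower number less inhibition), compound 1 gives > 80%, which is a limit of the assay.
Compound 2 `Clc1ccc(-c2nc(N3CCCCC3)c3nc[nH]c3n2)cc1Cl`: in this assay compound 2 gives > 80%, which is a limit of the assay.
Compound 3 `Clc1ccc(-c2nc(N3CCCCC3)c3nc[nH]c3n2)cc1`: in this assay compound 3 gives > 80%, which is a limit of the assay.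

Compound 4 `CN1CCN(c2nc(-c3cc(Cl)ccc3Cl)nc3[nH]cnc23)CC1` has not yet been measured. The difference between the core of compound 1 and the core of compound 3 is not broken down here. Compound 4 differs from compound 1 by chloro in place of hydrogen on an aromatic carbon. Compound 2 differs from compound 3 by chloro in place of hydrogen on an aromatic carbon. The two are the same kind of change, though not the same: in compound 4 the entering chloro is ortho to a large group and para to a chloro group, whereas in compound 2 it is ortho to a chloro group and meta to a large group. The measured step is a step that the two limits leave unreadable from compound 3 to compound 2, so its size is not readable. All three values shown sit at the limit of > 80% in this assay, at which 3 of the 3 values shown sit.

Compound 4 is expected to give 88% in this assay. The expected step is therefore a step that the limit leaves unreadable from compound 1 to compound 4. This expectation rests on compound 1, whose value > 80% is a limit of the assay. It rests also on the step that the two limits leave unreadable from compound 3 to compound 2, in which the same kind of chloro entry gave no readable change.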

Compound 4, a percentage reported as inhibition, at one concentration (the size of the read-out at that concentration, not a potency): > 80%
Compound 4: a limit, no number; the forecaster's own chance of this, stated with the estimate: 80%; the middle value does not contradict the limit.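

In this assay compound 4 gives > 80%, which is a limit of the assay and not a number. Compound 1 also stands at a limit, so the step between compound 1 and compound 4 cannot be read. The compounds shown leave open whether the entering chloro changes inhibition at all, because every value sits at one limit: the limit of > 80% in this assay, at which 4 of the 4 values shown sit.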